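The source may report more compounds than this note shows. Statements on the series, on what has been measured and on what is new or still open speak of the compounds shown alone.

For the measured compounds named here, compound 3, `COc1ccc(SC)c(NCC2=NCCN2)c1`, gives 5.01 nM in a functional assay for agonist activity at Alpha-1D adrenergic receptor (Homo sapiens) (on this read-out lower numbers stand for an effect already at smaller amounts and higher numbers for an effect only at larger amounts of compound), and holds the lowest of the two numbers known. Its nearest neighbour is compound 2, `CSc1ccc(F)cc1NCC1=NCCN1`, which in this assay gives 21.9 nM. Compound 1, `COc1ccc(S(C)(=O)=O)c(NCC2=NCCN2)c1`, returns in this assay only a limit, < 100000 nM. The one-place change a step that the limit leaves unreadable from compound 1 to compound 3 therefore cannot be sized, because of the limit of < 100000 nM in this assay, at which 1 of the 3 values shown sits. The other one-place change, a 4.4-fold lower number from compound 2 to compound 3 (0.64 log units; beyond the scatter), is modest but beyond the scatter.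

Compound 4, `CSc1ccc(C(F)(F)F)cc1NCC1=NCCN1`, is not yet measured. It differs from compound 3 in one place: trifluoromethyl in place of methoxy on an aromatic carbon. Going by the values given here, the only readable step on that carbon is the fluoro-to-methoxy change, a 4.4-fold lower number from compound 2 to compound 3 (0.64 log units; beyond the scatter), which shows that the methoxy group at this position gives a lower number than fluoro. Trifluoromethyl is neither of these, so compound 4 is expected to land nearer the fluoro compound 2 than compound 3, and the step of a 6.0-fold higher number from compound 3 to compound 4 (0.78 log units; beyond the scatter) is the estimate that follows. Compound 4 is thus estimated at 30 nM in this assay, with a plausible range from 8 nM to 120 nM; a reading at the limit is considered unlikely.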

Compound 4, half-maximal effective concentration: 43.7 nM
Estimate against measurement, compound 4: 1.5-fold (0.16 log units) below, within the range that was stated.
By their numbers in this assay, from the lowest: compound 3; then compounds 2 and 4 (each within the scatter of the next).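

Replacing methoxy with trifluoromethyl on this aromatic carbon gives an 8.7-fold higher number from compound 3 to compound 4 (0.94 log units; beyond the scatter) in this assay, so a second group now stands apart from methoxy and the advantage seen against fluoro is no longer a single comparison. Trifluoromethyl and fluoro, by contrast, are not separated: the change between them gives a 2.0-fold higher number from compound 2 to compound 4 (0.30 log units; within the scatter). Among the three groups shown at this place, which is para to the methylsulfanyl group, methoxy is therefore the only one that stands out, with compound 3 set apart from both compound 2 and compound 4, and no compound goes against this within the set. Nothing measured here bears on why these steps arise.

The compounds shown leave open whether the hydrogen-bond acceptor that leaves with methoxy has any part in the step, which a hydroxyl group or an amine on the same carbon would begin to address. They also leave open whether a longer chain such as ethoxy would stay with compound 3 or join compounds 2 and 4.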